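The source may report more compounds than this note shows. Statements on the series, on what has been measured and on what is new or still open speak of the compounds shown alone.

Notes on the series. Compound 2 `NCc1ccc(C(=O)Nc2ccncc2F)cc1-c1cccc(C(=O)OC2CCCOC2)c1` gives 8.7 nM in an assay on isolated protein for inhibition of Rho-associated protein kinase 2 (Homo sapiens), read by radiometric assay (a lower number here means a stronger inhibitor, a higher number a weaker inhibitor), and stands together with compound 1 `COC(=O)c1cccc(-c2cc(C(=O)Nc3ccncc3F)ccc2CN)c1`, which gives 7.8 nM; the step of a 1.1-fold higher number from compound 1 to compound 2 (0.05 log units; within the scatter) lies within the scatter. Compound 3 `NCc1ccc(C(=O)Nc2ccncc2F)cc1-c1cccc(C(=O)OCC2CCCC2)c1` differs from compound 2 by cyclopentylmethyl in place of oxan-3-yl on an oxygen next to a carbonyl group. Among the measured compounds shown here, the one step that bears on this is a 1.1-fold higher number from compound 1 to compound 2 (0.05 log units; within the scatter), where the group on the same oxygen was also exchanged and the number did not move beyond the scatter. No step beyond the scatter is therefore expected in either direction. Compound 3 is estimated at 10 nM, range 4 nM to 25 nM, a step of a 1.1-fold higher number from compound 2 to compound 3 (0.06 log units; within the scatter) expected.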

Compound 3, half-maximal inhibitory concentration: 13 nM
Beside the measured number, compound 3's estimate is 1.3-fold (0.11 log units) below it; the measured number falls inside the stated range.
By their numbers in this assay, from the lowest: compounds 1, 2 and 3 (each within the scatter of the next).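

On the oxygen next to a carbonyl group, cyclopentylmethyl in place of oxan-3-yl removes the ring oxygen and its hydrogen-bond acceptor, and the result is a 1.5-fold higher number from compound 2 to compound 3 (0.17 log units; within the scatter), so in this assay that acceptor is not shown to matter here. Against the methyl group of compound 1 the result is a 1.7-fold higher number from compound 1 to compound 3 (0.22 log units; within the scatter), so this all-carbon ring on a chain carbon also stays within the scatter. No supporting data explain this flat response.

On these data alone, whether an amine or a carboxylic acid at the end of a longer chain on this oxygen would give a step beyond the scatter remains open.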